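Swapping the benzyl substituent on a sigma ligand

The source may report more compounds than this note shows. Statements on the series, on what has been measured and on what is new or still open speak of the compounds shown alone.

Compound 1 `CN(CCCc1cn(-c2ccc(F)cc2)c2ccccc12)Cc1ccccc1` gives 20.8 nM in an assay on liver for displacement of a labelled ligand from Sigma non-opioid intracellular receptor 1 (Rattus norvegicus); on this read-out higher numbers stand for weaker inhibition and lower numbers for stronger inhibition.
Compound 2 `CN(CCCc1cn(-c2ccc(F)cc2)c2ccccc12)Cc1cccc(Cl)c1` gives 98.9 nM in this assay.

Going by the values given here, only two compounds have been measured so far, and compound 2 stands at the higher of the two numbers, with compound 1 as its only neighbour. Among the compounds with values here, the single measured step, a 4.8-fold higher number from compound 1 to compound 2 (0.68 log units; beyond the scatter), shows that adding a chloro group to the benzyl ring weakened the binding by a modest but real margin.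

The next compound, compound 3 `Cc1ccc(CN(C)CCCc2cn(-c3ccc(F)cc3)c3ccccc23)cc1C`, keeps the shared core and changes only the benzyl substituent: 3,4-dimethylphenyl in place of 3-chlorophenyl on a saturated chain carbon bound to an amine nitrogen. Within the data shown here, no measured pair speaks directly to a methyl-for-chloro exchange, so the only guidance is that a substituted benzyl ring in compound 2 gave a weaker result than the bare ring in compound 1. Compound 3 again carries a substituted ring, so a number in the same general region as compound 2 seems most likely, with little reason to expect a step beyond the scatter in either direction. Compound 3 is therefore estimated at 70 nM in this assay, with a range from 18 nM to 280 nM, corresponding to an expected step of a 1.4-fold lower number from compound 2 to compound 3 (0.15 log units; within the scatter).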

Compound 3, inhibition constant: 118 nM
Compound 3: the middle estimate sits 1.7-fold (0.23 log units) below what was measured, and the stated range covers the measured number.
By their numbers in this assay, from the lowest: compound 1; then compounds 2 and 3 (each within the scatter of the next).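

Exchanging 3-chlorophenyl for 3,4-dimethylphenyl on a saturated chain carbon bound to an amine nitrogen gives a 1.2-fold higher number from compound 2 to compound 3 (0.08 log units; within the scatter) in this assay, so these two substituted rings cannot be told apart on this read-out, even though one carries a chlorine and the other two methyl groups. Set against the bare phenyl ring, the same 3,4-dimethylphenyl group gives a 5.7-fold higher number from compound 1 to compound 3 (0.75 log units; beyond the scatter), so among these three compounds both substituted rings bind more weakly than the unsubstituted one, and no compound shown goes against this. No other information is available to explain why the chloro and dimethyl rings give such similar results.

The compounds shown leave open whether any group on this ring gives weaker binding, or whether a smaller or different one, such as a single fluorine or a methoxy group, would keep the number close to that of compound 1 (20.8 nM). They also leave open whether replacing the benzene ring itself with a pyridine ring, or lengthening the chain that carries the amine, would change the result at all.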